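Trifluoromethyl on the amide-bearing ring of compound 1

The source may report more compounds than this note shows. Statements on the series, on what has been measured and on what is new or still open speak of the compounds shown alone.

Compound 1 `O=C(Nc1ccccn1)c1cc2n(n1)CCCC2` is the parent of this set. In a functional assay on HEK293 cells for negative allosteric modulation of metabotropic glutamate receptor 5 (Rattus norvegicus), read by FLIPR and calcium flux, with a stated time of 170 s (on this read-out lower numbers stand for stronger inhibition and higher numbers for weaker inhibition), compound 1 gives 364 nM, the highest of the two numbers reported, with compound 3 nearest at a lower number. Compound 2 `O=C(Nc1ncccc1O)c1cc2n(n1)CCCC2` carries a hydroxy on the same ring; in this assay compound 2 reaches only > 10000 nM, which is a limit of the assay and not a number (the limit of > 10000 nM in this assay, at which 1 of the 3 values shown sits). Compound 3 `O=C(Nc1ccc(F)cn1)c1cc2n(n1)CCCC2` carries a fluoro; in this assay compound 3 gives 60 nM.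

Two steps from compound 1 are known: an at least 27-fold higher number from compound 1 to compound 2 (1.43 log units; beyond the scatter), and a 6.1-fold lower number from compound 1 to compound 3 (0.78 log units; beyond the scatter).

Compound 4 `O=C(Nc1cccc(C(F)(F)F)n1)c1cc2n(n1)CCCC2` is not yet measured. It differs from compound 1 by trifluoromethyl in place of hydrogen on an aromatic carbon. Within the data shown here, the step shares with the fluoro of compound 3 the entry of fluorine atoms, but sits at a different place, next to the ring nitrogen, and no step with a trifluoromethyl group is available for this series. Among the measured compounds shown here, the hydroxy step of compound 2 is the only other guide and points the opposite way. The expected outcome is therefore a step of no more than modest size in either direction, a 1.5-fold lower number from compound 1 to compound 4 (0.16 log units; within the scatter).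

For compound 4 in this assay the estimate is 250 nM, between 60 nM and 1500 nM.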

Compound 4, half-maximal inhibitory concentration: "not active" (no number reported)
For compound 4 the study gives words and no number; there is nothing to compare the estimate with.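

In this assay, among these compounds, compound 4 is reported as "not active", in words and without a number, so no step from compound 1 to compound 4 can be read. The compounds shown leave open what number trifluoromethyl gives on this core, and whether the report for compound 4 matches the limit of compound 2: the limit of > 10000 nM in this assay, at which 1 of the 4 values shown sits.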